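The compounds below may be only part of what the source reports. "The series", "measured", "known", "first", "only" and "open" are said of these compounds alone.

Measured compounds:
compound 1 `CCCc1nc2ccccc2c(=O)n1/N=C/c1ccc(Oc2ccc(Cl)cc2)cc1` with 5.78
compound 2 `Cc1nc2ccccc2c(=O)n1/N=C/c1ccc(Oc2ccc(Cl)cc2)cc1` with 4.6
compound 3 `CCCc1nc2ccccc2c(=O)n1/N=C/c1ccc(Oc2ccc(Cl)c(C)c2)cc1` with 6.02

All three were measured in a physicochemical assay for lipophilicity, in phosphate buffer, measured as octanol-water partition; on this read-out higher numbers stand for higher lipophilicity and lower numbers for lower lipophilicity. Compound 2 stands lowest of the three; compound 1 lies nearest to it, the step being a number 1.18 log units lower from compound 1 to compound 2 (beyond the scatter), and compound 3 lies furthest, the two other compounds differing from each other by a number 0.24 log units higher from compound 1 to compound 3 (within the scatter). Compound 4 `Cc1nc2ccccc2c(=O)n1/N=C/c1ccc(Oc2ccc([N+](=O)[O-])cc2)cc1` has not been measured. It differs from compound 2 in one place: nitro in place of chloro on an aromatic carbon. Neither measured step touches this change, one swapping ethyl for hydrogen on the chain, the other adding methyl to a ring, so no direct guide exists. Compound 4 is nonetheless expected to give a lower number, the estimated step being a number 1.00 log units lower from compound 2 to compound 4 (beyond the scatter). Compound 4 is estimated at 3.6, within 3.1 to 4.1.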

Compound 4, partition coefficient: 4.01
For compound 4 the middle estimate is 0.41 log units below the measured one; low and high end bracket the measured number.
By their numbers in this assay, from the lowest: compound 4; then compound 2; then compounds 1 and 3 (each within the scatter of the next).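

In this assay the position held by the chloro of the 4-chlorophenoxy group proves sensitive to what sits there, with a number 0.59 log units lower from compound 2 to compound 4 (beyond the scatter) when nitro replaces chloro. Among these compounds, the earlier steps changed only the chain or added a methyl to a ring, so this is the first look at replacing the chloro itself, here with a group that carries hydrogen-bond acceptors. No supporting measurement accounts for this shift.

As far as these compounds go, how an amine or a carboxylic acid would read at this position remains open. So does whether the nitro step would hold on the longer chain of compound 1.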